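A few compounds are considered here, and "the series" means these few. Any claim that something is new, unique, unknown or untested is made for them only; others in the source may bear on it.

Compound 2 `O=c1ccoc2cc(OCc3cn(Cc4ccc(Br)cc4)nn3)ccc12` stands at a limit in a functional assay on A549 cells (Homo sapiens) for cytotoxicity, read by MTT assay, with a stated time of 48 h; a lower number here means a stronger inhibitor, a higher number a weaker inhibitor: for compound 2 only > 100000 nM is reported, a boundary rather than a number (the limit of > 100000 nM in this assay, at which 1 of the 2 values shown sits). Among the compounds with values here, compound 1 `O=c1ccoc2cc(OCc3cn(Cc4ccc(Cl)cc4Cl)nn3)ccc12` gives 5260 nM in this assay, and the single measured step, an at least 19-fold higher number from compound 1 to compound 2 (1.27 log units; beyond the scatter), ran up to that boundary. Compound 3 `O=c1ccoc2cc(OCc3cn(Cc4ccccc4Cl)nn3)ccc12` differs from compound 2 by 2-chlorophenyl in place of 4-bromophenyl on a saturated chain carbon bound to an aromatic nitrogen. Because compound 1, whose phenyl also carries a chlorine, gives 5260 nM, a step back toward a measurable number is expected, an at least 3.3-fold lower number from compound 2 to compound 3 (0.52 log units; beyond the scatter). Compound 3 is estimated at 30000 nM, between 8000 nM and 100000 nM, with a fair chance that only a limit is again reported.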

Compound 3, half-maximal inhibitory concentration: > 100000 nM
Compound 3: a limit, no number; the forecaster's own chance of this, stated with the estimate: 35%; at least 3.3-fold (0.52 log units) between middle value and limit.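

Compound 1 is the only one of the three with a measurable number, and a chlorine on the phenyl is not enough by itself: compound 3 keeps 2-chlorophenyl, yet hydrogen in place of chloro on an aromatic carbon gives an at least 19-fold higher number from compound 1 to compound 3 (1.27 log units; beyond the scatter). Compound 3 reports only a limit, not a number. The step from compound 2 to compound 3 cannot be read because both compounds stand at that limit: the limit of > 100000 nM in this assay, at which 2 of the 3 values shown sit.

On these data alone, how far beyond the limit either compound lies stays open. So does whether a methoxy group on the phenyl, or a longer chain in place of the benzyl carbon, would restore a measurable number.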